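The source may hold more compounds than are shown below. What is called first, only, known or untested is meant among the compounds shown, and "the series" means these compounds.

Compound 1 `CCC(C)n1ncn(-c2ccc(N3CCN(c4ccc(OC[C@@H]5CO[C@@](CBr)(c6ccc(Cl)cc6Cl)O5)cc4)CC3)cc2)c1=O` stands highest of the two numbers available in a functional assay on HUVEC cells (Homo sapiens), read by scintillation counting and thymidine incorporation, with a stated time of 24 h (a higher number here means a weaker inhibitor, a lower number a stronger inhibitor), where compound 1 gives 569 nM. Going by the values given here, compound 2 `CCc1nccn1C[C@@]1(c2ccc(Cl)cc2Cl)OC[C@@H](COc2ccc(N3CCN(c4ccc(-n5cnn(C(C)CC)c5=O)cc4)CC3)cc2)O1` gives 224 nM in this assay, and the step of a 2.5-fold lower number from compound 1 to compound 2 (0.40 log units; beyond the scatter) records the single exchange that separates those two compounds. Compound 3 `CCC(C)n1ncn(-c2ccc(N3CCN(c4ccc(OC[C@@H]5CO[C@@](Cn6nnnc6-c6ccccc6)(c6ccc(Cl)cc6Cl)O5)cc4)CC3)cc2)c1=O` carries a related change at the same place: 5-phenyl-1H-tetrazol-1-yl in place of bromo on a saturated chain carbon bound to a saturated ring carbon. Among the compounds with values here, the only measured step that bears on it is a 2.5-fold lower number from compound 1 to compound 2 (0.40 log units; beyond the scatter), a modest drop when a five-membered aromatic ring entered there. A similar modest drop is expected here, a 2.3-fold lower number from compound 1 to compound 3 (0.36 log units; beyond the scatter). Compound 3 is therefore estimated at 250 nM, within a range of 120 nM to 550 nM.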

Compound 3, half-maximal inhibitory concentration: 119 nM
Beside the measured number, compound 3's estimate is 2.1-fold (0.32 log units) above it; measured number below the stated range.
By their numbers in this assay, from the lowest: compounds 3 and 2 (each within the scatter of the next); then compound 1.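

In this assay, the saturated chain carbon bound to a saturated ring carbon accepts the much larger 5-phenyl-1H-tetrazol-1-yl in place of bromo, with a 4.8-fold lower number from compound 1 to compound 3 (0.68 log units; beyond the scatter) as the result. Set against 2-ethyl-1H-imidazol-1-yl, the tetrazole gives a 1.9-fold lower number from compound 2 to compound 3 (0.27 log units; within the scatter) and so cannot be told apart from it. Nothing available explains why either ring group gives a lower number than bromo.

The compounds shown leave open whether an aromatic ring is needed at this place at all. A simple amine or a carboxylic acid on the same carbon would help to answer that.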